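The source may hold more compounds than are shown below. What is called first, only, known or untested is meant among the compounds shown, and "the series" means these compounds.

Measured compounds:
- compound 1, `CCCCCCC[C@@H]1CC(=O)N[C@H](CC(C)C)C(=O)N[C@@H](CO)C(=O)N[C@@H]([C@@H](C)O)C(=O)N[C@H](CC(C)C)C(=O)N[C@@H]([C@@H](C)CC)C(=O)O1`: "not determined" (no result reported) in a functional assay on HCT-116 cells (Homo sapiens) for cytotoxicity; a lower number here means a stronger inhibitor, a higher number a weaker inhibitor
- compound 2, `CCCCCC/C=C\CCC[C@@H]1CC(=O)N[C@H](CC(C)C)C(=O)N[C@@H](CO)C(=O)N[C@@H]([C@@H](C)O)C(=O)N[C@H](CC(C)C)C(=O)N[C@@H]([C@@H](C)CC)C(=O)O1`: 28000 nM in this assay

Compound 1 carries no result in this assay, so it stands nowhere on the numbers shown; the only figure for the series is that of compound 2, which in this assay gives 28000 nM, a weak value. Among the measured compounds shown here, compound 2 differs from compound 1 in its chain, which is longer and carries a double bond, and no step between the two is given.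

Compound 3, `CC[C@H](C)[C@@H]1NC(=O)[C@@H](CC(C)C)NC(=O)[C@H]([C@@H](C)O)NC(=O)[C@H](CO)NC(=O)[C@@H](CC(C)C)NC(=O)C[C@@H](CCCCCCCCC(C)C)OC1=O`, is the next compound to be measured in this assay. It differs from compound 1 as follows: isobutyl in place of hydrogen on a saturated chain carbon, seven bonds along the chain from a saturated ring carbon. With no measured step of this kind in the series, the expected size of the step from compound 1 to compound 3 in this assay is uncertain and is taken as small, with no clear direction, and possibly none beyond the scatter.

Taking the weak result of compound 2 in this assay, 28000 nM, as the only anchor, compound 3 is estimated at 20000 nM in this assay, within a range of 5000 nM to 80000 nM.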

Compound 3, half-maximal inhibitory concentration: 17000 nM
Compound 3: the middle estimate sits 1.2-fold (0.07 log units) above what was measured, and the stated range covers the measured number.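

Among the compounds shown here, the first readable step in this assay is a 1.6-fold lower number from compound 2 to compound 3 (0.22 log units; within the scatter) and it replaces one group of 8 heavy atoms with another, on a saturated chain carbon, three bonds along the chain from a saturated ring carbon. The chain of compound 2 with its double bond and the chain of compound 3 ending in isobutyl therefore give values within the scatter of each other on the shared core, so this exchange shows no separable effect on the read-out, and both compounds remain weak. Nothing available explains this result or shows how either chain acts in these cells.

From the compounds shown here alone, the step from compound 1 to compound 3 cannot be read, so what isobutyl adds to the chain of compound 1 remains open in this assay and the role of chain length cannot be judged from these compounds. Also open, going by these compounds, is whether any other group on this chain can move the value out of the weak range, for instance a much longer chain, an amine or a carboxylic acid.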